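The source may report more compounds than this note shows. Statements on the series, on what has been measured and on what is new or still open speak of the compounds shown alone.

Compound 1 `CS(=O)(=O)NNc1nonc1/C(=N/O)Nc1ccc(F)c(Br)c1` gives 609 nM in an assay on isolated protein for inhibition of Indoleamine 2,3-dioxygenase 1 (Homo sapiens), read by fluorescence, with a stated time of 60 min; a higher number here means a weaker inhibitor, a lower number a stronger inhibitor. Among the compounds with values here, compound 2 `NS(=O)(=O)NNc1nonc1/C(=N/O)Nc1ccc(F)c(Br)c1` gives 218 nM in this assay, the lowest of the two numbers; the single step seen so far, a 2.8-fold lower number from compound 1 to compound 2 (0.45 log units; beyond the scatter), lies beyond the scatter. Compound 3 `O=S1(=O)CC(Nc2nonc2/C(=N/O)Nc2ccc(F)c(Br)c2)C1` differs from compound 2 by a group of 6 heavy atoms (3 carbon, 2 oxygen, 1 sulfur; one four-membered non-aromatic ring with 1 hetero atom) in place of a group of 5 heavy atoms (2 nitrogen, 2 oxygen, 1 sulfur; no ring), on a nitrogen on an aromatic ring. Within the data shown here, no measured step alters this part of the molecule in a comparable way, so the expectation rests on the change itself and stays uncertain. Compound 3 is expected to give about 600 nM, somewhere between 150 nM and 2500 nM. That estimated step, a 2.8-fold higher number from compound 2 to compound 3 (0.44 log units; beyond the scatter), would point toward a higher number, though a result within the scatter remains possible.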

Compound 3, half-maximal inhibitory concentration: 99 nM
The estimate for compound 3 lay 6.1-fold (0.78 log units) above the measured number; measured number outside the range, below it.
By their numbers in this assay, from the lowest: compound 3; then compound 2; then compound 1.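

Replacing the open sulfamoylamino group with the four-membered ring gives a 2.2-fold lower number from compound 2 to compound 3 (0.34 log units; beyond the scatter), and the same ring set against the group of compound 1 gives a 6.2-fold lower number from compound 1 to compound 3 (0.79 log units; beyond the scatter). The position on the nitrogen therefore accepts a ring, and the hydrogen-bond donors of the sulfamoylamino group are not needed for a lower number in this assay. Nothing measured here speaks to the cause of these steps. Still open, from the compounds shown here alone, is whether the ring itself or its sulfonyl group matters: an oxetane ring or a five-membered sulfone ring in the same place would separate the two.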